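Notes on the aryl-nitrogen substituent of the shared core

This account rests on a few compounds, and the source may have more. Where it says the series, first, only, none or still open, it means among the compounds named here.

Compound 1 `COc1ccc(S(=O)(=O)N2CCc3cccc(NS(=O)(=O)c4ccccc4)c32)cc1` carries a phenylsulfonyl on a nitrogen on an aromatic ring, and in a functional assay on MKN-45 cells (Homo sapiens) for cytotoxicity (on this read-out lower numbers stand for stronger inhibition and higher numbers for weaker inhibition), compound 1 gives 562 nM. Compound 2 `COc1ccc(S(=O)(=O)N2CCc3cccc(NC(=O)N(C)c4ccccc4)c32)cc1` carries a methyl(phenyl)carbamoyl at that nitrogen instead. In this assay compound 2 gives > 10000 nM, which is a limit of the assay and not a number. The step is an at least 17-fold higher number from compound 1 to compound 2 (1.25 log units; beyond the scatter); because the limit of > 10000 nM in this assay, at which 1 of the 2 values shown sits, only a lower bound on the gap is known. Compound 2 thus stands at the weak end of what has been measured. Compound 3 `COc1ccc(S(=O)(=O)N2CCc3cccc(N)c32)cc1` differs from compound 2 by hydrogen in place of methyl(phenyl)carbamoyl on a nitrogen on an aromatic ring. Among the measured compounds shown here, no measured step removes a group at this nitrogen; the single step known, an at least 17-fold higher number from compound 1 to compound 2 (1.25 log units; beyond the scatter), exchanges two groups there and so bears on the present change only indirectly. The expected step in this assay is an at least 1.2-fold lower number from compound 2 to compound 3 (0.09 log units; that floor lies within the scatter). Compound 3 is estimated at 8000 nM, in the range 1500 nM to 30000 nM.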

Compound 3, half-maximal inhibitory concentration: 1200 nM
The estimate for compound 3 lay 6.7-fold (0.82 log units) above the measured number; measured number outside the range, below it.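

Hydrogen on this nitrogen gives the series a reference point that the earlier compounds lacked, and in this assay the two substituents fall on opposite sides of it. Removing the methyl(phenyl)carbamoyl restores measurable activity, with an at least 8.3-fold lower number from compound 2 to compound 3 (0.92 log units; beyond the scatter), while hydrogen in place of phenylsulfonyl costs only a modest amount, with a 2.1-fold higher number from compound 1 to compound 3 (0.33 log units; beyond the scatter): the phenylsulfonyl stands on the stronger side of hydrogen and the methyl(phenyl)carbamoyl on the weaker side. Compound 2 sits at a limit of the assay, not at a number, so the first of these steps is only a floor: the limit of > 10000 nM in this assay, at which 1 of the 3 values shown sits.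

From the compounds shown here alone, it remains open whether the phenyl ring of the phenylsulfonyl matters, which a methylsulfonyl at this nitrogen would address. A phenylcarbamoyl, lacking the methyl, would show whether that methyl contributes to the weakness of compound 2.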